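Cyclobutyl to (tert-butyl)amino on a sulfonyl sulfur

The compounds below may be only part of what the source reports. "The series", "measured", "known", "first", "only" and "open" are said of these compounds alone.

Of the compounds shown here, two have numbers so far in a functional assay on MIA PaCa-2 cells (Homo sapiens) for inhibition, read by MTT assay, with a stated time of 7 days; a lower number here means a stronger inhibitor, a higher number a weaker inhibitor. Compound 1 `CCN(CC)S(=O)(=O)c1ccc(S(=O)(=O)N2CCC[C@@H](C(=O)NC3CCN(C(=O)OC(C)(C)C)CC3)C2)cc1` gives 100 nM, and compound 2 `CC(C)c1noc(N2CCN(C(=O)[C@@H]3CCCN(S(=O)(=O)c4ccc(S(=O)(=O)C5CCC5)cc4)C3)CC2)n1` gives 70 nM. These two values lie within the scatter of each other, so compound 2 stands level with compound 1 on the numbers available.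

Compound 3 `CC(C)c1noc(N2CCN(C(=O)[C@@H]3CCCN(S(=O)(=O)c4ccc(S(=O)(=O)NC(C)(C)C)cc4)C3)CC2)n1` has not yet been measured. It departs from compound 2 in one place: (tert-butyl)amino in place of cyclobutyl on a sulfonyl sulfur. Cut one bond further out, the same change reads cyclobutylsulfonyl to (tert-butyl)sulfamoyl. Among the compounds with values here, no measured pair differs in one place only, so the data give no direct guide to the size of this change.

The only support is indirect: compound 1 at 100 nM and compound 2 at 70 nM stay within the scatter despite their different structures. In this assay, no change beyond the scatter is therefore expected, and neither direction is favoured. The estimated step of a 1.1-fold higher number from compound 2 to compound 3 (0.06 log units; within the scatter) is small. For compound 3 the estimate is 80 nM, with an expected range of 30 nM to 220 nM.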

Compound 3, half-maximal inhibitory concentration: 300 nM
Beside the measured number, compound 3's estimate is 3.8-fold (0.57 log units) below it; the measured number lies above the stated range.
By their numbers in this assay, from the lowest: compounds 2 and 1 (each within the scatter of the next); then compound 3.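

Within the data shown here, the first single-place step shows that this position is sensitive: in this assay, putting (tert-butyl)amino in place of cyclobutyl on a sulfonyl sulfur gives a 4.3-fold higher number from compound 2 to compound 3 (0.63 log units; beyond the scatter) and moves compound 3 clear of the level pair formed by compound 1 and compound 2. The change alters several things at once, as the ring of carbon only leaves and an open group with a hydrogen-bond donor enters, so the step cannot be assigned to any one of these differences. Nothing measured here accounts for the size or direction of this step.

The compounds shown leave open whether the loss of the ring or the entry of the amino hydrogen carries the step, and a cyclobutylamino group or a plain tert-butyl group on the same sulfur would separate the two. Also open, from the compounds shown here alone, is where other groups on this sulfur, such as cyclopropyl or morpholinyl, would fall relative to compound 2 and compound 3.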